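The source may report more compounds than this note shows. Statements on the series, on what has been measured and on what is new or still open speak of the compounds shown alone.

In an ADME assay on MT4 cells (Homo sapiens) for cytotoxicity, read by spectrophotometry, with a stated time of 5 days (a lower number here means that less compound is tolerated, a higher number that more compound is tolerated), compound 1 `Cc1ccc2c(c1)/C(=N/NC(=S)NO)C(=O)N2CN(C)C` gives 651000 nM, so a high concentration is needed before the cells are harmed. Compound 2 `CONC(=S)N/N=C1\C(=O)N(CN(C)C)c2ccc(C)cc21` gives 622000 nM, and the two sit level: the step is a 1.0-fold lower number from compound 1 to compound 2 (0.02 log units; within the scatter). Compound 3 `CCn1cc(C(=O)O)c(=O)c2cc(F)c(N3CCN(CN4C(=O)/C(=N\NC(=S)NO)c5cc(Cl)ccc54)C(C)C3)c(F)c21` gives 209000 nM, a lower number than compound 1 by more than the usual scatter, and it differs from compound 1 in more than one place.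

The next comparison is compound 4 `CN(C)CN1C(=O)/C(=N\NC(=S)NO)c2cc(Cl)ccc21`, which differs from compound 1 by a single swap: chloro in place of methyl on an aromatic carbon. Chloro replaces methyl on an aromatic carbon, while the rest of the molecule stays the same. Within the data shown here, no measured step covers this swap. Among the measured compounds shown here, the one measured step, a 1.0-fold lower number from compound 1 to compound 2 (0.02 log units; within the scatter), concerns a different place in the molecule, so it gives only weak guidance. For the measured compounds named here, compound 3, at 209000 nM, is the only measured compound that carries chloro, but its other differences prevent the lower number from being tied to chloro. A small downward move therefore seems the safest expectation, with a wide margin. The expected change is a 1.4-fold lower number from compound 1 to compound 4 (0.16 log units; within the scatter). For compound 4 the estimated value is 450000 nM, with an expected range from 200000 nM to 800000 nM.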

Compound 4, half-maximal cytotoxic concentration: 610000 nM
The estimate for compound 4 lay 1.4-fold (0.13 log units) below the measured number, within the range that was stated.
By their numbers in this assay, from the lowest: compound 3; then compounds 4, 2 and 1 (each within the scatter of the next).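

In this assay, the swap at this aromatic carbon gives a 1.1-fold lower number from compound 1 to compound 4 (0.03 log units; within the scatter), so methyl and chloro on the six-membered aromatic ring sit level, and the cells tolerate the two compounds alike as far as repeated measurements can tell. Until now, chloro had appeared only in compound 3, which differs from compound 1 in more than one place, so nothing could be said about chloro by itself; this pair isolates that one change and shows no difference beyond the scatter. No measurement of any property of these groups is available to explain why the two compounds sit level.

The compounds shown cover only methyl and chloro at this position, so it remains open whether a larger or quite different group there, such as methoxy, nitro, an amine or a carboxylic acid, would also leave the number level. On these data alone, it also remains open whether chloro would stay level with methyl when the hydrogen on the oxygen is replaced by methyl, as it is in compound 2.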